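A few compounds are considered here, and "the series" means these few. Any claim that something is new, unique, unknown or untested is made for them only; others in the source may bear on it.

Measured compounds:
compound 1 `CCO/N=C/Nc1cc(Cl)c(OC)c(Cl)c1` — in a physicochemical assay for lipophilicity, measured as octanol-water partition (a higher number here means a more lipophilic compound, a lower number a more polar compound), compound 1 gives 3.7
compound 2 `C#CCc1c(Cl)cc(N/C=N/OCOC)cc1Cl` — in this assay compound 2 gives 3.2

Compound 2 holds the lower of these two numbers; compound 1 sits higher by a gap that exceeds the usual scatter of repeated measurements of this kind. Among the measured compounds shown here, the two compounds differ in several places at once, so no single-point step between measured compounds is available to lean on.

Compound 3 `C#CCc1c(Cl)cc(N/C=N/Oc2ccc(C)cc2)cc1Cl` has not yet been measured in this assay. It differs from compound 2 in one place: 4-methylphenyl in place of methoxymethyl on an oxygen. The measured pair does not show what this particular change does, so the expectation rests on the change itself rather than on an observed step. Compound 3 is expected to come out clearly more lipophilic than compound 2, an estimated step of a number 1.70 log units higher from compound 2 to compound 3 (beyond the scatter), well beyond the scatter. Compound 3 is therefore expected to give about 4.9, with a range from 4.3 to 5.5.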

Compound 3, partition coefficient: 4.8
Estimate against measurement, compound 3: 0.10 log units above; measured number inside the range.
By their numbers in this assay, from the lowest: compound 2; then compound 1; then compound 3.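

Among the compounds shown here, this gives the first single-place step: on an oxygen whose other neighbour is a double-bonded nitrogen, 4-methylphenyl in place of methoxymethyl gives a number 1.60 log units higher from compound 2 to compound 3 (beyond the scatter) in this assay. The size of this step shows that the group on this oxygen alone can move the number by a large amount while the rest of compound 2 stays unchanged. The entering group brings more heavy atoms and a six-membered aromatic ring of carbon only, and it lacks the hydrogen-bond acceptor of the leaving group, but nothing available separates these differences or explains the step.

Still open, as far as these compounds go, is how a plain phenyl, without its methyl, would compare on this oxygen. A longer chain or a carboxylic acid there also remains untested among the compounds shown.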